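A Dichlorophenyl Group Gives Way to Methoxyphenyl

The source may hold more compounds than are shown below. What is called first, only, known or untested is meant among the compounds shown, and "the series" means these compounds.

In an ADME assay on MDBK cells (Bos taurus) for cytotoxicity, read by MTT assay (a higher number here means that more compound is tolerated, a lower number that less compound is tolerated), compound 1 (`OC[C@@H]1[C@@H](O)[C@H](O)[C@@H](O)CN1CCCc1cccc(OC2CCCCC2)c1`) gives 390000 nM and compound 2 (`OC[C@@H]1[C@@H](O)[C@H](O)[C@@H](O)CN1CCCCCCOc1cc(Cl)ccc1Cl`) gives 320000 nM, so these two values lie within the usual scatter of each other. Compound 3 (`COc1ccccc1OCCCCCCN1C[C@H](O)[C@@H](O)[C@H](O)[C@H]1CO`) has 2-methoxyphenyl in place of 2,5-dichlorophenyl on an oxygen on a saturated carbon. For the measured compounds named here, no measured pair shows what this exchange does, so no step beyond the scatter is expected in this assay. The expected step is small, an estimated 1.2-fold higher number from compound 2 to compound 3 (0.07 log units; within the scatter). For compound 3, the estimated value is 380000 nM, with a range of 170000 nM to 850000 nM.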

Compound 3, half-maximal cytotoxic concentration: > 500000 nM
Compound 3: a limit, no number; the forecaster's own chance of this, stated with the estimate: 15%; middle value at least 1.3-fold (0.11 log units) from the limit.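

In this assay, for the compounds shown here, this is the first reading of 2-methoxyphenyl in place of 2,5-dichlorophenyl on an oxygen on a saturated carbon, with a step of an at least 1.5-fold higher number from compound 2 to compound 3 (0.19 log units; that floor lies within the scatter) for the exchange. Compound 3 gives > 500000 nM, which is a limit and not a number. The step is therefore only a floor: it shows no loss of tolerance with this change but establishes no real gain, and its true size stays hidden by this evidence: the limit of > 500000 nM in this assay, at which 1 of the 3 values shown sits.

On these data alone, it remains open how far compound 3 lies beyond the limit. Also open, as far as these compounds go, is what an amine or a carboxylic acid on the phenyl ring, or a longer chain, would do here.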